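The compounds below may be only part of what the source reports. "The series", "measured", "known", "first", "only" and "open" are said of these compounds alone.

Compound 1 `Cc1cn(C2CCN(Cc3cccc(Oc4ccccc4)n3)CC2)c(=O)[nH]c1=O`: > 64000 nM (a limit)
Compound 2 `Cc1cn(C2CCN(Cc3ccnc(Oc4ccccc4)c3)CC2)c(=O)[nH]c1=O`: > 64000 nM (a limit)
Compound 3 `Cc1cn(C2CCN(Cc3cccc(Oc4cccc(C(F)(F)F)c4)c3)CC2)c(=O)[nH]c1=O`: 12400 nM

These compounds were tested in an ADME assay on MRC5 cells (Homo sapiens) for cytotoxicity, read by fluorescence and resazurin assay, with a stated time of 3 days; on this read-out lower numbers stand for stronger inhibition and higher numbers for weaker inhibition. Compound 1 gives > 64000 nM, which is a limit of the assay and not a number. Compound 2 gives > 64000 nM, which is also a limit. Compound 2 therefore has no exact value and stands at the limit of > 64000 nM in this assay, at which 2 of the 3 values shown sit.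

Compound 4 `Cc1cn(C2CCN(Cc3ccnc(Oc4cccc(Cl)c4)c3)CC2)c(=O)[nH]c1=O` differs from compound 2 by a single change: chloro in place of hydrogen on an aromatic carbon. Put simply, the phenoxy group becomes a 3-chlorophenoxy group, with chloro in place of hydrogen on an aromatic carbon.

Going by the values given here, no measured pair of compounds here isolates this change, so any forecast is tentative. Among the compounds with values here, the only clue is compound 3, which carries a trifluoromethyl group on its phenoxy ring and gives a measured 12400 nM. On that slender basis, a modest shift towards lower numbers, and so stronger inhibition, is expected, although compound 4 may still reach the limit of the assay.

The estimate for compound 4 is 40000 nM, with an expected range from 16000 nM to 64000 nM. This estimate corresponds to an expected at least 1.6-fold lower number from compound 2 to compound 4 (0.20 log units; that floor lies within the scatter).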

Compound 4, half-maximal inhibitory concentration: > 64000 nM
Compound 4: only a limit was reported; the forecaster's own chance of this, stated with the estimate: 45%; middle value at least 1.6-fold (0.20 log units) away from the limit.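

In this assay compound 4 gives > 64000 nM, which is a limit of the assay and not a number. Going by these compounds alone, compound 2 gives > 64000 nM, also a limit, so no step between compound 2 and compound 4 can be read. Going by these compounds, whether chloro in place of hydrogen on an aromatic carbon changes the read-out at all, and by how much, stays open.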